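Swapping the aryl group on a pyrazole core

This account rests on a few compounds, and the source may have more. Where it says the series, first, only, none or still open, it means among the compounds named here.

Measured so far:
Compound 1 `Cc1nn(-c2nc(-c3ccc(Cl)c(Cl)c3)c(SC(C)C)s2)c(C(=O)O)c1-c1cncnc1` gives 22000 nM in a functional assay on BJAB cells (Homo sapiens) for antiproliferative activity, with a stated time of 4 days; on this read-out lower numbers stand for an effect already at smaller amounts and higher numbers for an effect only at larger amounts of compound.
Compound 2 `Cc1nn(-c2nc(-c3ccc(Cl)c(Cl)c3)c(SC(C)C)s2)c(C(=O)O)c1-c1cnccn1` gives 14000 nM.
Compound 3 `Cc1nn(-c2nc(-c3ccc(Cl)c(Cl)c3)c(SC(C)C)s2)c(C(=O)O)c1-c1cc(C#N)cc(C(F)(F)F)c1` gives 3600 nM.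

Compound 3 shows the lowest number of the three, with the steps of a 6.1-fold lower number from compound 1 to compound 3 (0.79 log units; beyond the scatter) and a 3.9-fold lower number from compound 2 to compound 3 (0.59 log units; beyond the scatter) both beyond the scatter. Compound 4 `Cc1nn(-c2nc(-c3ccc(Cl)c(Cl)c3)c(SC(C)C)s2)c(C(=O)O)c1-c1cccc(F)c1` differs from compound 3 in one place: 3-fluorophenyl in place of 3-cyano-5-(trifluoromethyl)phenyl on an aromatic carbon. Among the compounds with values here, both measured steps to compound 3 replaced a six-membered ring with nitrogen by a six-membered ring of carbon only; compound 4 keeps the carbon-only ring, yet no measured pair tests such a change on that ring itself, so the direction is uncertain. A modest upward step is expected, a 1.9-fold higher number from compound 3 to compound 4 (0.29 log units; within the scatter), giving compound 4 an estimated 7000 nM with a range from 2500 nM to 20000 nM.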

Compound 4, half-maximal effective concentration: 900 nM
Beside the measured number, compound 4's estimate is 7.8-fold (0.89 log units) above it; the measured number lies below the stated range.
By their numbers in this assay, from the lowest: compound 4; then compound 3; then compounds 2 and 1 (each within the scatter of the next).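

At this aromatic carbon, more heavy atoms on the carbon-only ring do not bring a lower number: 3-fluorophenyl in place of 3-cyano-5-(trifluoromethyl)phenyl gives a 4.0-fold lower number from compound 3 to compound 4 (0.60 log units; beyond the scatter). Against the rings containing nitrogen, the gaps are larger, with a 16-fold lower number from compound 2 to compound 4 (1.19 log units; beyond the scatter) and a 24-fold lower number from compound 1 to compound 4 (1.39 log units; beyond the scatter). Nothing available explains these steps.

Going by these compounds, what the single fluorine contributes remains open, and a plain phenyl ring would test that directly. On these data alone, it is also open whether a methoxy group or an amine on this ring would lower the number further.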